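A few compounds are considered here, and "the series" means these few. Any claim that something is new, unique, unknown or untested is made for them only; others in the source may bear on it.

Three compounds share one core and differ only in the group attached to the amide carbonyl. Compound 1 `O=C(Nc1cc2cc[nH]c(=O)c2cc1Cl)[C@H]1CCCN1` carries a saturated ring on that carbonyl carbon; in an assay on isolated protein for inhibition of Rho-associated protein kinase 2 (Homo sapiens) (a lower number here means a stronger inhibitor, a higher number a weaker inhibitor), compound 1 gives 130 nM. Compound 2 `CC(C)C[C@H](N)C(=O)Nc1cc2cc[nH]c(=O)c2cc1Cl` has an open chain in the same place, and in this assay compound 2 gives 340 nM, a change of a 2.6-fold higher number from compound 1 to compound 2 (0.42 log units; beyond the scatter). Compound 3 `CC(C)N[C@H](C(=O)Nc1cc2cc[nH]c(=O)c2cc1Cl)C1CCCCC1` carries a larger, substituted chain, and in this assay compound 3 gives 25 nM, the lowest of the three numbers. Compound 1 therefore stands second highest of the three, nearer to compound 2 than to compound 3.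

Compound 4 `O=C(Nc1cc2cc[nH]c(=O)c2cc1Cl)[C@@H]1CCCN1` is the mirror image of compound 1 at its only stereocentre: the two compounds have the same atoms and bonds and differ only in configuration as drawn: 1 of 1 stereo elements differ; a stereocentre at a saturated ring carbon is drawn R in compound 1 and S in compound 4. Going by the values given here, none of the measured steps alters configuration alone; the steps among compound 1, compound 2 and compound 3 all change which atoms are present, so they give no direct guide to how inverting a single centre moves the number in this assay. Mirror-image pairs of this kind often give clearly different numbers, and with nothing to favour the inverted form, compound 4 is expected to give a higher number, a step of a 3.5-fold higher number from compound 1 to compound 4 (0.54 log units; beyond the scatter). The estimate for compound 4 is 450 nM, within a range of 100 nM to 2500 nM.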

Compound 4, half-maximal inhibitory concentration: 35 nM
Compound 4: middle estimate off by 13-fold (1.11 log units), on the high side; the whole stated range lies above it.
By their numbers in this assay, from the lowest: compounds 3 and 4 (each within the scatter of the next); then compound 1; then compound 2.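

Inverting the single ring stereocentre is enough on its own to move the number in this assay, with a 3.7-fold lower number from compound 1 to compound 4 (0.57 log units; beyond the scatter), and this gap belongs to configuration alone, because no atom or bond changes: the fact that compounds 1 and 4 differ only in the configuration as drawn. The earlier steps shown here all changed atoms, so they could not separate the effect of the group on the carbonyl carbon from the way that group is drawn in space. The comparison between ring and open chain now also depends on configuration, since the first form of the ring gives a 2.6-fold higher number from compound 1 to compound 2 (0.42 log units; beyond the scatter) while the inverted form gives a 9.7-fold lower number from compound 2 to compound 4 (0.99 log units; beyond the scatter), and the small pyrrolidin-2-yl group of compound 4 at 35 nM lies within the scatter of the larger substituted chain of compound 3 at 25 nM as its number.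

The compounds shown leave open whether inverting the matching centre in compound 2 or compound 3 would move the number in the same direction. They also leave open whether the inverted configuration would keep its advantage with a larger piperidin-2-yl ring, or with an isopropyl group on the pyrrolidine nitrogen.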